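The compounds below may be only part of what the source reports. "The series", "measured", "known", "first", "only" and "open" are said of these compounds alone.

Compound 1 `CC(=O)c1c(C)[n+]([O-])c2cc(-n3ccnc3)c(F)cc2[n+]1[O-]`: 95700 nM
Compound 2 `CC(=O)c1c(C(F)(F)F)[n+]([O-])c2cc(-n3ccnc3)c(F)cc2[n+]1[O-]`: 46500 nM

These numbers come from an ADME assay on Vero cells (Chlorocebus sabaeus) for cytotoxicity, read by MTT assay, with a stated time of 72 h; a lower number here means a stronger inhibitor, a higher number a weaker inhibitor. Of the two measured compounds, compound 1 stands highest at 95700 nM, which makes it the weaker inhibitor of the pair.

Compound 3 `CCOC(=O)c1c(C)[n+]([O-])c2cc(-n3ccnc3)c(F)cc2[n+]1[O-]` has not yet been measured. It keeps the core of compound 1 and changes one group: ethoxy in place of methyl on a carbonyl carbon. Put simply, ethoxy takes the place of methyl on a carbonyl carbon, turning acetyl to ethoxycarbonyl.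

For the measured compounds named here, only one measured step is available, and it involves a different change, trifluoromethyl in place of methyl on an aromatic carbon. That step, a 2.1-fold lower number from compound 1 to compound 2 (0.31 log units; beyond the scatter), is modest and offers only a loose guide to size. Going by the values given here, no measured compound carries ethoxycarbonyl, so the data set no firm direction. In this assay, a small shift toward a lower number is expected, with nothing clearly beyond the scatter. The expected step is a 1.4-fold lower number from compound 1 to compound 3 (0.14 log units; within the scatter). For compound 3 the estimate is 70000 nM, with an expected range from 30000 nM to 150000 nM.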

Compound 3, half-maximal inhibitory concentration: 129000 nM
For compound 3 the middle estimate is 1.8-fold (0.27 log units) below the measured one, within the range that was stated.
By their numbers in this assay, from the lowest: compound 2; then compounds 1 and 3 (each within the scatter of the next).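

Replacing methyl with ethoxy on the carbonyl carbon, which turns acetyl into ethoxycarbonyl, gives a 1.3-fold higher number from compound 1 to compound 3 (0.13 log units; within the scatter) in this assay and so leaves no readable difference between the two compounds. For the compounds shown here, this is the first view of the carbonyl carbon, since the earlier step, a 2.1-fold lower number from compound 1 to compound 2 (0.31 log units; beyond the scatter), came from a change on an aromatic carbon and was the only one beyond the scatter. Here, a group of more heavy atoms that also brings a hydrogen-bond acceptor enters at the carbonyl carbon, yet the reading stays within the normal variation of repeated measurements, and no measurement available explains this result.

This single change cannot show whether the carbonyl carbon would stay just as unresponsive with a carboxylic acid, an amide bearing a simple amine, or an ester with a longer chain such as butoxy in place of ethoxy. As far as these compounds go, it also remains open whether ethoxycarbonyl and trifluoromethyl together on the shared core would give a number that simply follows from the two separate changes.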